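Side-chain change from compound 2 to compound 3

A few compounds are considered here, and "the series" means these few. Any claim that something is new, unique, unknown or untested is made for them only; others in the source may bear on it.

Measured so far in a physicochemical assay for lipophilicity, read by HPLC, at pH 7.5; on this read-out higher numbers stand for higher lipophilicity and lower numbers for lower lipophilicity
- compound 1 `CCOc1ccccc1-c1ccc(-c2nc3cnccc3c(N[C@H](CC)C(N)=O)c2C#N)cc1` reads 3 here
- compound 2 `CCOc1ccccc1-c1ccc(-c2nc3cnccc3c(NC(COC)C(N)=O)c2C#N)cc1` reads 2.8 here

Going by the values given here, only one step connects the measured compounds, and it is a number 0.20 log units lower from compound 1 to compound 2 (within the scatter) in this assay on this pair. Compound 2 therefore cannot be told apart from compound 1 on these numbers.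

Compound 3 `CCOc1ccccc1-c1ccc(-c2nc3cnccc3c(NC(CC)CNS(=O)(=O)C3CC3)c2C#N)cc1` differs from compound 2 by a group of 11 heavy atoms (7 carbon, 1 nitrogen, 2 oxygen, 1 sulfur; one three-membered non-aromatic ring of carbon only) in place of a group of 7 heavy atoms (4 carbon, 1 nitrogen, 2 oxygen; no ring), on a nitrogen on an aromatic ring and the shared core stays as it is. Among the compounds with values here, the step of a number 0.20 log units lower from compound 1 to compound 2 (within the scatter) sits at the same place and is small, but no measured step covers a group with sulfur or a three-membered non-aromatic ring of carbon only, so the guidance is weak. Starting from compound 2 at 2.8 and counting more carbon in the entering group, a rise beyond the scatter is expected. The expected size is a number 0.60 log units higher from compound 2 to compound 3 (beyond the scatter) and remains uncertain. For compound 3 the estimate is 3.4 with an expected range of 2.9 to 3.9 in this assay on this series.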

Compound 3, distribution coefficient: 3.6
Beside the measured number, compound 3's estimate is 0.20 log units below it; measured number inside the range.
By their numbers in this assay, from the lowest: compounds 2 and 1 (each within the scatter of the next); then compound 3.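

In this assay, the group with sulfur and the three-membered non-aromatic ring of carbon only gives a number 0.80 log units higher from compound 2 to compound 3 (beyond the scatter) and a number 0.60 log units higher from compound 1 to compound 3 (beyond the scatter). The substituent on the nitrogen on an aromatic ring can therefore shift this read-out beyond the scatter, which the exchange of 1-carbamoylpropyl for 1-carbamoyl-2-methoxyethyl did not show. No measurement on hand accounts for the rise.

The entering group differs in size, ring and sulfur all at once, so the shift cannot be assigned to any one of these features. A methyl group on the sulfur in place of the three-membered ring, or an amine or carboxylic acid at this place, would test how far the read-out depends on each part of the group.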